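From a Butyl Chain to a Cyclohexyl Ring

A few compounds are considered here, and "the series" means these few. Any claim that something is new, unique, unknown or untested is made for them only; others in the source may bear on it.

Compound 1, `NC(=O)c1ccn(-c2cccc(OC(=O)NCCCCCCc3ccccc3)c2)c1`, gives 0.6 nM in an assay (brain) for inhibition of Fatty-acid amide hydrolase 1 (Mus musculus), with stated times of 20 min and 15 min; a higher number here means a weaker inhibitor, a lower number a stronger inhibitor.
Compound 2, `C#CCCCCCCCCCOC(=O)c1ccn(-c2cccc(OC(=O)NCCCCCCc3ccccc3)c2)c1`, gives > 200 nM in this assay; that figure is a limit of the assay, not a number.
Compound 3, `CCCCNC(=O)Oc1cccc(-c2oc(C)cc2C(N)=O)c1`, gives 530 nM in this assay.

Going by the values given here, only one step between compounds that differ in a single place is measured: an at least 330-fold higher number from compound 1 to compound 2 (2.52 log units; beyond the scatter). Its size is set partly by the limit of > 200 nM in this assay, at which 1 of the 3 values shown sits, so the true step may be larger still. Compound 3 stands at the highest of the two proper numbers; its nearest neighbour, compound 1, sits far lower, well beyond the scatter.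

Compound 4, `Cc1cc(C(N)=O)c(-c2cccc(OC(=O)NC3CCCCC3)c2)o1`, is the next compound to be measured. Its relation to compound 3 is cyclohexyl in place of butyl on an amide-type nitrogen. Among the compounds with values here, the single measured step changed a different place on a different core, so no measured step bears on this change, and no size or direction can be read from it. The expectation therefore rests on the modest scale of a swap between two saturated carbon groups on an amide-type nitrogen. Compound 4 is expected to give about 150 nM in this assay, within a range of 20 nM to 1000 nM. That estimate corresponds to an expected step of a 3.5-fold lower number from compound 3 to compound 4 (0.55 log units; beyond the scatter).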

Compound 4, half-maximal inhibitory concentration: > 70 nM
Compound 4 was reported as a limit (the forecaster's own chance of this, stated with the estimate: 5%); the middle value is on the limit's open side.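

Compound 4 gives > 70 nM in this assay, a limit of the assay and not a number. Going by these compounds alone, no step can therefore be read between compound 3 and compound 4. The compounds shown leave open whether cyclohexyl in place of butyl on the amide-type nitrogen gives a stronger or a weaker inhibitor, and by how much.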